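Methoxy in place of hydrogen: compound 2 to compound 3

The source may hold more compounds than are shown below. What is called first, only, known or untested is meant among the compounds shown, and "the series" means these compounds.

Measured so far:
compound 1 `COc1ccc(-c2nnc(SC/C(=N/O)c3ccccc3)n2-c2ccccc2)cc1` with 63%
compound 2 `O=C(CSc1nnc(-c2ccccc2)n1-c1ccccc1)c1ccccc1` with 60%

In a functional assay on the whole organism (strain albino) for inhibition, with Rattus norvegicus as the target, read by paw edema, with a stated time of 2 h, at a dose of 0.28 mmol/kg by the oral route (on this read-out lower numbers stand for less inhibition and higher numbers for more inhibition at the one dose given (going by the name of the read-out)), compound 1 gives 63%, and compound 2 gives 60%. Compound 2 holds the lower of the two numbers, yet its nearest neighbour, compound 1, sits within the scatter, so no order follows. The two differ in more than one place, and their values show only that both lie close together.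

Compound 3 `COc1ccc(-c2nnc(SCC(=O)c3ccccc3)n2-c2ccccc2)cc1` awaits measurement. Against compound 2 it shows (methoxy in place of hydrogen on an aromatic carbon). Within the data shown here, no step between measured compounds exists to calibrate this change. From compound 2 to compound 3 a step of a number 2 percentage points higher from compound 2 to compound 3 (within the scatter) is expected, none beyond the scatter. Compound 3 is estimated at 62%, range 50% to 74%.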

Compound 3, a percentage reported as inhibition, in the whole organism at one dose (the size of the read-out at that dose, not a potency): 57%
The estimate for compound 3 lay 5 percentage points above the measured number; the range from low to high includes it.
By their numbers in this assay, from the lowest: compounds 3, 2 and 1 (each within the scatter of the next).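

In this assay the change from phenyl to 4-methoxyphenyl gives a number 3 percentage points lower from compound 2 to compound 3 (within the scatter), so methoxy on this aromatic carbon brings no readable shift at the one dose given. On the saturated chain carbon bound to a sulfur, the exchange of groups gives a number 6 percentage points lower from compound 1 to compound 3 (within the scatter), which likewise shows no readable shift. No measurement at hand bears on either step.

Going by these compounds, whether an amine or a carboxylic acid on that aromatic carbon would move the number beyond the scatter stays open. So does the effect of a longer chain on the sulfur.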